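A Vinyl Group in Place of Two Methyl Groups

A few compounds are considered here, and "the series" means these few. Any claim that something is new, unique, unknown or untested is made for them only; others in the source may bear on it.

In a functional assay on HCT-116 cells (Homo sapiens) for inhibition, read by CCK-8 assay, with a stated time of 48 h (a lower number here means a stronger inhibitor, a higher number a weaker inhibitor), compound 1 (`COc1cc(-c2cc3nccc(-c4cc(OC)c(OC)c(OC)c4)n3n2)cc(OC)c1OC`) reports > 10000 nM only as a limit. Compound 2 (`COc1cc(-c2cc3nccc(-c4c[nH]c5ccccc45)n3n2)cc(OC)c1OC`) likewise reports > 10000 nM only as a limit. Compound 3 (`COc1cc(-c2ccnc3cc(-c4ccc(C)c(C)c4)nn23)cc(OC)c1OC`) gives 261 nM and is the only one of the three with an actual number.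

Compound 4 (`C=Cc1ccc(-c2cc3nccc(-c4cc(OC)c(OC)c(OC)c4)n3n2)cc1`) is unmeasured and carries 4-vinylphenyl in place of 3,4-dimethylphenyl on an aromatic carbon. For the measured compounds named here, no measured pair isolates this exchange. Both groups are six-membered aromatic rings of carbon only, so the expectation stays anchored on compound 3 at 261 nM with no shift beyond the scatter in this assay in either direction. The expected step of a 1.1-fold higher number from compound 3 to compound 4 (0.06 log units; within the scatter) is small. Compound 4 is estimated at 300 nM with an expected range from 80 nM to 1500 nM as its likely span.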

Compound 4, half-maximal inhibitory concentration: 1060 nM
Compound 4: middle estimate off by 3.5-fold (0.55 log units), on the low side, and the stated range covers the measured number.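

In this assay, exchanging 3,4-dimethylphenyl for 4-vinylphenyl keeps the ring type and the heavy-atom count, yet the number still moves: a 4.1-fold higher number from compound 3 to compound 4 (0.61 log units; beyond the scatter). This position therefore responds to what the phenyl ring carries, not only to the presence of that ring. Compound 4 still gives an actual number, whereas other values shown stop at a limit: the limit of > 10000 nM in this assay, at which 2 of the 4 values shown sit.

This single step cannot separate the removal of the two methyl groups from the arrival of the vinyl group. From the compounds shown here alone, how an amine or a carboxylic acid on the phenyl ring would fare at this position stays open.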